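The compounds below may be only part of what the source reports. "The series", "measured", "known", "first", "only" and "open" are said of these compounds alone.

In a functional assay on HepG2 cells (Homo sapiens) for cytotoxicity, read by MTT assay, with a stated time of 48 h (on this read-out higher numbers stand for weaker inhibition and lower numbers for stronger inhibition), compound 1 `CN(C)CCNc1ccnc2cc(OCc3ccccc3)ccc12` gives 3120 nM, and compound 2 `CCOc1ccc2c(NCCN(C)C)ccnc2c1` gives 5680 nM; the two numbers lie within the scatter of each other, so neither stands apart. Compound 3 `CCCCCCOc1ccc2c(NCCN(C)C)ccnc2c1` differs from compound 2 by butyl in place of hydrogen on a saturated chain carbon, two bonds along the chain from an oxygen on an aromatic ring. Within the data shown here, the only measured step, a 1.8-fold higher number from compound 1 to compound 2 (0.26 log units; within the scatter), concerns a different exchange on that chain carbon and was within the scatter, so it offers no direct guide to lengthening the chain; no step beyond the scatter is expected in this assay. Compound 3 is therefore expected at 5000 nM, between 1500 nM and 16000 nM. That estimate means a step of a 1.1-fold lower number from compound 2 to compound 3 (0.06 log units; within the scatter).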

Compound 3, half-maximal inhibitory concentration: 1370 nM
Beside the measured number, compound 3's estimate is 3.6-fold (0.56 log units) above it, and the stated range ends above it.
By their numbers in this assay, from the lowest: compound 3; then compounds 1 and 2 (each within the scatter of the next).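

In this assay, among these compounds, ethoxy to hexyloxy gives the first step at this position that lies beyond the scatter (a 4.1-fold lower number from compound 2 to compound 3 (0.62 log units; beyond the scatter)). Pentyl in place of phenyl on the saturated chain carbon bound to an oxygen on an aromatic ring also goes beyond the scatter (a 2.3-fold lower number from compound 1 to compound 3 (0.36 log units; beyond the scatter)), whereas methyl in place of phenyl there did not. Nothing available explains these steps.

As far as these compounds go, whether a longer chain would carry the trend further remains open. So does whether a chain ending in an amine or a carboxylic acid would keep the step.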